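Changing the amide substituent in an oral lung exposure series

The source may report more compounds than this note shows. Statements on the series, on what has been measured and on what is new or still open speak of the compounds shown alone.

The series shares one core and varies the group on an amide-type nitrogen. Compound 1 `CONC(=O)c1cccc(Oc2cc(CN)cc(C(F)(F)F)n2)c1` was tested in an ADME assay on the whole organism (lung, Mus musculus) for pharmacokinetics, read by LC-MS, at a dose of 30 mg/kg by the oral route (a lower number here means less compound in the circulation, a higher number more compound in the circulation at the dose given), and gives 8780 nM. Among the measured compounds shown here, compound 2 `NCc1cc(Oc2cccc(C(=O)NCCn3cnnn3)c2)nc(C(F)(F)F)c1` gives 3460 nM in the same setting, which makes compound 2 the lower of the two numbers measured so far; the one measured step, a 2.5-fold lower number from compound 1 to compound 2 (0.40 log units; beyond the scatter), separates them. Compound 3 `NCc1cc(Oc2cccc(C(=O)NC[C@@H](O)CO)c2)nc(C(F)(F)F)c1` has not yet been measured; it differs from compound 2 by 1,2-dihydroxyethyl in place of (1H-tetrazol-1-yl)methyl on a saturated chain carbon bound to an amide-type nitrogen. For the measured compounds named here, no measured step covers this particular change: the step from compound 1 to compound 2 concerns a different replacement at the same amide-type nitrogen and was only modest. Going by the values given here, with no direct precedent, compound 3 is expected to land close to compound 2, with a step of a 1.2-fold lower number from compound 2 to compound 3 (0.06 log units; within the scatter) that may well stay within the scatter. Compound 3 is therefore estimated at 3000 nM, with a range from 1200 nM to 7500 nM.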

Compound 3, maximal plasma concentration: 1920 nM
Beside the measured number, compound 3's estimate is 1.6-fold (0.19 log units) above it, and the stated range covers the measured number.
By their numbers in this assay, from the lowest: compounds 3 and 2 (each within the scatter of the next); then compound 1.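

In this assay, the change shows a 1.8-fold lower number from compound 2 to compound 3 (0.26 log units; within the scatter) and so leaves compound 2 and compound 3 within the scatter of each other, even though the 2-(1H-tetrazol-1-yl)ethyl group has one five-membered aromatic ring and 0 hydrogen-bond donors, while the 2,3-dihydroxypropyl group has no ring and 2 hydrogen-bond donors. Measured against methoxy, 2,3-dihydroxypropyl gives a 4.6-fold lower number from compound 1 to compound 3 (0.66 log units; beyond the scatter) and thus, like 2-(1H-tetrazol-1-yl)ethyl, stands beyond the scatter from compound 1, with no listed compound going against this. No evidence is available to explain these results.

On these data alone, whether an amine, a carboxylic acid or a longer chain on this amide-type nitrogen would fall with compound 2 and compound 3 or nearer compound 1 remains open. As far as these compounds go, the mirror-image form of the 2,3-dihydroxypropyl group also remains open.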